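The compounds below may be only part of what the source reports. "The series", "measured", "known", "first", "only" and "open" are said of these compounds alone.

Measured compounds in the series:
- compound 1 `Cc1noc(C)c1C(c1ccccc1)N1CCN(c2ncnc3c2cnn3-c2ccccc2)CC1`: > 25000 nM
- compound 2 `c1ccc(C(c2ccco2)N2CCN(c3ncnc4c3cnn4-c3ccccc3)CC2)cc1`: > 25000 nM
- compound 3 `Cc1ccccc1C(c1sccc1C)N1CCN(c2ncnc3c2cnn3-c2ccccc2)CC1`: > 25000 nM

Each of these three values in a functional assay on cells (Rhabdomyosarcoma cell, Homo sapiens) for cytotoxicity (a higher number here means a weaker inhibitor, a lower number a stronger inhibitor), is a limit of the assay and not a number. Among the compounds with values here, compound 2 therefore stands at the limit in this assay, and its position relative to the other two cannot be read; the values of compound 1 and compound 3 show only that neither gave a number either. Within the data shown here, the one step between neighbours, a step that the two limits leave unreadable from compound 1 to compound 2, is unreadable because the limit of > 25000 nM in this assay, at which 3 of the 3 values shown sit, holds both of its ends.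

Compound 4 `c1ccc(C(c2ccccn2)N2CCN(c3ncnc4c3cnn4-c3ccccc3)CC2)cc1` differs from compound 2 by pyridin-2-yl in place of furan-2-yl on a saturated chain carbon bound to an amine nitrogen in a ring and an aromatic carbon. Among the measured compounds shown here, no measured step with a readable size bears on this change; the only step involving compound 2 sits wholly at the limit. The expectation for compound 4 in this assay therefore rests on the three limits alone, and no step beyond the scatter is expected from a number no higher from compound 2 to compound 4 (the limit leaves the size open). For compound 4 the estimated value in this assay is 25000 nM, with an expected range from 8000 nM to 50000 nM, and the most likely outcome is that compound 4 is again reported only as a limit.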

Compound 4, half-maximal inhibitory concentration: > 25000 nM
Compound 4 gave a limit, no number; the forecaster's own chance of this, stated with the estimate: 80%; the middle value sits exactly at the limit.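

In this assay compound 4 gives only a limit of the assay and not a number, and the steps from compound 1 to compound 4 and from compound 2 to compound 4 cannot be read because both ends of each sit at one limit: the limit of > 25000 nM in this assay, at which 4 of the 4 values shown sit.

The compounds shown leave open whether any replacement of the group on this saturated chain carbon gives a readable value.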